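Saturating the linker: compound 3 to compound 4

The source may report more compounds than this note shows. Statements on the series, on what has been measured and on what is new or still open speak of the compounds shown alone.

Measured compounds:
compound 1 `COc1cc2nc(/C=C/c3ccccn3)nc(N3CCC(CCNS(N)(=O)=O)CC3)c2cc1OC` gives 71 nM
compound 2 `COc1cc2nc(/C=C/c3ccncc3)nc(N3CCC(CCNS(N)(=O)=O)CC3)c2cc1OC` gives 218 nM
compound 3 `COc1cc2nc(/C=C/c3ccc(F)cc3)nc(N3CCC(CCNS(N)(=O)=O)CC3)c2cc1OC` gives 465 nM

All three numbers come from an assay on cells for inhibition of Ectonucleotide pyrophosphatase/phosphodiesterase family member 1 (Homo sapiens), with a stated time of 60 min; a lower number here means a stronger inhibitor, a higher number a weaker inhibitor. Compound 3 stands at the highest number of the three, so it is the weakest of them: the step of a 6.5-fold higher number from compound 1 to compound 3 (0.82 log units; beyond the scatter) and the step of a 2.1-fold higher number from compound 2 to compound 3 (0.33 log units; beyond the scatter) both lie beyond the scatter, as does the step of a 3.1-fold higher number from compound 1 to compound 2 (0.49 log units; beyond the scatter).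

Compound 4 `COc1cc2nc(CCc3ccc(F)cc3)nc(N3CCC(CCNS(N)(=O)=O)CC3)c2cc1OC` is not yet measured. It differs from compound 3 by 2-(4-fluorophenyl)ethyl in place of 2-(4-fluorophenyl)ethenyl on an aromatic carbon. The change keeps the same ring and the same count of atoms and only removes the double bond from the chain that joins the ring to the shared core.

Going by the values given here, none of the measured steps bears on this change: all three swap the ring at the end of the chain and leave the chain itself untouched. There is therefore no measured guide, and the expectation rests on compound 3 alone. A step of modest size toward a higher number is expected, a 1.9-fold higher number from compound 3 to compound 4 (0.29 log units; within the scatter), close to the scatter. Compound 4 is expected to give about 900 nM, with a range from 250 nM to 3500 nM.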

Compound 4, inhibition constant: 366 nM
Estimate against measurement, compound 4: 2.5-fold (0.39 log units) above; measured number inside the range.
By their numbers in this assay, from the lowest: compound 1; then compounds 2, 4 and 3 (each within the scatter of the next, the first and the last beyond it).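

In this assay, the step of a 1.3-fold lower number from compound 3 to compound 4 (0.10 log units; within the scatter) lies within the scatter, so at this aromatic carbon 2-(4-fluorophenyl)ethyl and 2-(4-fluorophenyl)ethenyl cannot be told apart, and the double bond is not needed to hold the number at this level when a 4-fluorophenyl ring ends the chain. The step of a 1.7-fold higher number from compound 2 to compound 4 (0.23 log units; within the scatter) also lies within the scatter, whereas a 5.2-fold higher number from compound 1 to compound 4 (0.71 log units; beyond the scatter) lies beyond it, so the saturated chain leaves compound 1 clearly apart from compound 4. No measurement here explains why removing the double bond leaves so little mark on the number.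

As far as these compounds go, it remains open whether 2-(pyridin-2-yl)ethyl would match the number of its double-bonded partner, compound 1. A longer chain, or an amine or ether oxygen within the chain, also remains unexplored among the compounds shown.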